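The source may report more compounds than this note shows. Statements on the series, on what has been measured and on what is new or still open speak of the compounds shown alone.

Working notes on the series, all read in a functional assay on HEp-2 cells (Homo sapiens) for inhibition; a higher number here means that more compound is needed for the effect, a lower number that less compound is needed. Compound 1 `CSc1ncnc2[nH]nnc12` gives > 300 uM. That value is a limit of the assay and not a number. Compound 2 `CSc1ncnc2c1nnn2[C@@H]1O[C@H](COC(C)=O)[C@@H](OC(C)=O)[C@H]1OC(C)=O` gives 0.5 uM. Compound 3 `CCSc1ncnc2c1nnn2[C@@H]1O[C@H](CO)[C@@H](O)[C@H]1O` gives 0.1 uM, the lower of the two actual numbers, and its gap to compound 2 lies beyond the scatter.

The next compound to be read is compound 4 `CC(C)=CCNc1ncnc2c1nnn2[C@@H]1O[C@H](CO)[C@@H](O)[C@H]1O`. It differs from compound 3 as follows: (3-methylbut-2-en-1-yl)amino in place of ethylsulfanyl on an aromatic carbon. In words, (3-methylbut-2-en-1-yl)amino stands in place of ethylsulfanyl on an aromatic carbon of a six-membered aromatic ring.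

Going by the values given here, no measured pair differs in one place, so no direct precedent exists for this replacement, and the size of the change is a judgement with wide margins. A move towards a higher number in this assay is expected, of moderate size and beyond the scatter. Compound 2 at 0.5 uM and compound 3 at 0.1 uM both return numbers, so a number rather than a limit is expected for compound 4. The expected step is a 10-fold higher number from compound 3 to compound 4 (1.00 log units; beyond the scatter). For compound 4 the estimated value is 1 uM, with an expected range of 0.1 uM to 10 uM.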

Compound 4, concentration for half-maximal effect: < 3 uM
Compound 4 gave a limit, no number; the forecaster's own chance of this, stated with the estimate: 5%; the middle value does not contradict the limit.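

In this assay compound 4 gives < 3 uM, which is a limit of the assay and not a number, and no size can be read for the step between compound 3 and compound 4. The compounds shown leave open whether (3-methylbut-2-en-1-yl)amino in place of ethylsulfanyl gives a higher number, a lower number or no change beyond the scatter.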